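The compounds below may be only part of what the source reports. "The series", "measured", "known", "first", "only" and "open" are said of these compounds alone.

Of the compounds shown here, three have been measured in a functional assay on IGROV-1 cells (Homo sapiens) for cytotoxicity, read by sulforhodamine B assay, with a stated time of 48 h; a higher number here means a weaker inhibitor of growth, a lower number a stronger inhibitor of growth. Compound 1 `ClCc1ccccc1Cn1cnc2c(Cl)ncnc21` gives 8910 nM in this assay. Compound 2 `ClCc1cccc(Cn2cnc3c(Cl)ncnc32)c1` gives 33900 nM in this assay. Compound 3 `ClCc1ccccc1Cn1cnc2ncnc(Cl)c21` gives 22900 nM in this assay. Among these three numbers compound 3 stands second highest. Its value and that of compound 2 lie within the usual scatter of each other, so nothing separates the two, whereas compound 1 gives a lower number than compound 3 by a margin beyond the scatter.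

The next compound is compound 4 `ClCc1ccccc1Cn1cnc2nc(Cl)nc(Cl)c21`. It differs from compound 3 in one place: chloro in place of hydrogen on an aromatic carbon. Going by the values given here, no pair of measured compounds shows what such an added chloro does, so there is no measured step to lean on, and the two measured pairs that do exist differ in other ways altogether. The expected step is therefore a 1.4-fold lower number from compound 3 to compound 4 (0.16 log units; within the scatter), a small one in either direction or none beyond the scatter. Compound 4 is accordingly expected to give 16000 nM in this assay, within a range from 5000 nM to 50000 nM.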

Compound 4, concentration for total growth inhibition: 5240 nM
Estimate against measurement, compound 4: 3.1-fold (0.48 log units) above, and the stated range covers the measured number.
By their numbers in this assay, from the lowest: compounds 4 and 1 (each within the scatter of the next); then compounds 3 and 2 (each within the scatter of the next).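

In this assay, going by these compounds alone, chloro in place of hydrogen on an aromatic carbon gives a 4.4-fold lower number from compound 3 to compound 4 (0.64 log units; beyond the scatter) and so provides the first measured step between compounds that differ in one place. It shows that the place between two ring nitrogen atoms, on the six-membered aromatic ring with 2 nitrogen, is not indifferent to this change: a single chlorine atom there, meta to the chloro group already present, moves the concentration for total growth inhibition by more than the usual scatter of repeated measurements. Nothing at hand accounts for this step, so it stands as an observation only.

Whether the step belongs to chloro in particular stays open, as no other group at this place, such as an amine, a methoxy group or a methyl group, appears among the compounds shown. From the compounds shown here alone, it also remains open whether the same added chloro would bring a step of similar size to compound 1 or to compound 2 and whether the chloromethyl group on the benzyl ring matters to the result.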